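This account rests on a few compounds, and the source may have more. Where it says the series, first, only, none or still open, it means among the compounds named here.

Among the measured compounds shown here, compound 1 `Cc1ccc(-c2cs/c(=N/NC(=O)CSc3nncn3C)n2-c2ccccc2)cc1` is one of two compounds measured in a functional assay on C6 cells (Rattus norvegicus) for cytotoxicity, read by MTT assay, with a stated time of 24 h, tested at 25 ug/mL; a lower number here means a stronger effect, a higher number a weaker effect of the compound at the concentration tested. In this assay compound 1 gives 70.7%, the higher of the two numbers recorded so far. The other measured compound, compound 2 `Cc1ccc(-c2cs/c(=N/NC(=O)CSc3nnnn3C)n2-c2ccccc2)cc1`, gives 60.7%. The step of a number 10 percentage points lower from compound 1 to compound 2 (within the scatter) puts 1-methyl-1H-tetrazol-5-yl in place of 4-methyl-4H-1,2,4-triazol-3-yl on a sulfur and stays within the usual scatter.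

Compound 3 `Cn1cnnc1SCC(=O)N/N=c1/scc(-c2ccccc2)n1-c1ccccc1` has not yet been measured in this assay. It differs from compound 1 as follows: hydrogen in place of methyl on an aromatic carbon. Cut one bond further out, the same difference reads 4-methylphenyl to phenyl.

For the measured compounds named here, the single measured step, from compound 1 to compound 2, changes the ring attached to the sulfur and leaves the six-membered aromatic ring of carbon only untouched. So no measured step bears directly on the change in compound 3, and that step was itself within the scatter. With the loss of only one methyl, no shift beyond the scatter is expected; the step of a number 1.3 percentage points higher from compound 1 to compound 3 (within the scatter) is expected to be small. For compound 3 the estimate is 72%, expected to fall between 55% and 88%.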

Compound 3, a percentage reported as activity, at one concentration (the size of the read-out at that concentration, not a potency): 77.3%
Beside the measured number, compound 3's estimate is 5.3 percentage points below it, within the range that was stated.
By their numbers in this assay, from the lowest: compounds 2, 1 and 3 (each within the scatter of the next, the first and the last beyond it).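

In this assay, among the compounds shown here, replacing 4-methylphenyl with phenyl gives a number 6.6 percentage points higher from compound 1 to compound 3 (within the scatter) and offers the first measured look at this part of the molecule, since the earlier step changed only the ring on the sulfur. That step lies within the scatter, so this assay cannot tell the methyl from a hydrogen at this place on the six-membered aromatic ring of carbon only, para to a large group, and nothing here shows that the methyl matters for the read-out at the concentration tested. No measurement available here explains this result or points to a reason for it.

On these data alone, removing a single methyl is a small probe, so it remains open whether a chlorine, a methoxy group, an amine or a carboxylic acid at the same place would move the number beyond the scatter. It is also unknown whether the change from 4-methylphenyl to phenyl would give a step of similar size in a compound carrying 1-methyl-1H-tetrazol-5-yl on the sulfur, as compound 2 does.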